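The compounds below may be only part of what the source reports. "The series", "measured", "known", "first", "only" and "open" are said of these compounds alone.

In an ADME assay on L6 cells (Rattus norvegicus) for cytotoxicity, read by resazurin assay, with a stated time of 72 h (a lower number here means a stronger inhibitor, a higher number a weaker inhibitor), compound 1 `O=C(NC(=O)c1ccccc1O)c1ccc(F)cc1` gives 38 ug/mL, compound 2 `O=C(NC(=O)c1ccccc1O)c1ccc(OC(F)(F)F)cc1` gives 84 ug/mL and compound 3 `CCOc1ccc(C(=O)NC(=O)c2ccccc2O)cc1` gives 17 ug/mL, the lowest number of the three. Compound 4 `COC(=O)CCC(=O)Nc1ccc(C(=O)NC(=O)c2ccccc2O)cc1` carries ((2-(methoxycarbonyl)ethyl)carbonyl)amino in place of ethoxy on an aromatic carbon. The measured changes at this place are modest but beyond the scatter, with a 2.2-fold higher number from compound 1 to compound 2 (0.34 log units; beyond the scatter) between the two compounds that lack ethoxy. The steps of a 2.2-fold lower number from compound 1 to compound 3 (0.35 log units; beyond the scatter) and a 4.9-fold lower number from compound 2 to compound 3 (0.69 log units; beyond the scatter) both reach a lower number on arriving at ethoxy, so moving away from it is expected to raise the number. None of these steps tests a group like the incoming chain, so this expectation remains loose. A modest rise, a 2.4-fold higher number from compound 3 to compound 4 (0.37 log units; beyond the scatter), is therefore expected. In this assay, compound 4 is estimated at 40 ug/mL, with an expected range of 14 ug/mL to 95 ug/mL.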

Compound 4, half-maximal inhibitory concentration: > 50 ug/mL
Compound 4: only a limit was reported (the forecaster's own chance of this, stated with the estimate: 10%); at least 1.2-fold (0.09 log units) between middle value and limit.
By their numbers in this assay, from the lowest: compound 3; then compound 1; then compound 2.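

In this assay compound 4 is reported only as a limit, > 50 ug/mL. Exchanging ethoxy for the ((2-(methoxycarbonyl)ethyl)carbonyl)amino chain gives an at least 2.9-fold higher number from compound 3 to compound 4 (0.46 log units; beyond the scatter), which extends the range of groups tested at this aromatic carbon to a much larger chain with a nitrogen and shows that the number still rises beyond the scatter on leaving ethoxy. Exchanging fluoro for the same chain gives an at least 1.3-fold higher number from compound 1 to compound 4 (0.11 log units; that floor lies within the scatter), so the limit does not firmly separate that pair, and the step from trifluoromethoxy cannot be read.

The true size of the rise remains open, as does which part of the chain accounts for it. An amine, a carboxylic acid in place of the methyl ester, or a shorter chain at this place would help to separate these parts.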